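Methoxymethoxy added to a compound at the assay limit

The source may report more compounds than this note shows. Statements on the series, on what has been measured and on what is new or still open speak of the compounds shown alone.

In an ADME assay on HEK293 cells (Homo sapiens) for cytotoxicity, read by MTT assay, with a stated time of 72 h (a higher number here means a weaker inhibitor, a lower number a stronger inhibitor), compound 1 `COc1ccc(C2=C(c3cc(OC)c(OC)c(OC)c3)C(=O)CC2O[SiH2]C(C)(C)C)cc1` gives > 100 ug/mL, which is a limit and not a number. Compound 2 `COc1cc(C2=C(c3ccc(OCC(=O)O)cc3)C(O)CC2=O)cc(OC)c1OC` gives > 100 ug/mL, also a limit. Compound 3 `COc1ccc(C2=C(c3cc(OC)c(OC)c(OC)c3)C(=O)CC2O)cc1`, by contrast, gives a measured 10 ug/mL. Compound 1 therefore has no exact position, and (the limit of > 100 ug/mL in this assay, at which 2 of the 3 values shown sit).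

Compound 4 `COCOc1cc(C2=C(c3cc(OC)c(OC)c(OC)c3)C(=O)CC2O[SiH2]C(C)(C)C)ccc1OC` differs from compound 1 by methoxymethoxy in place of hydrogen on an aromatic carbon, with the new group ortho to a methoxy group. Two measured steps lead away from the limit, an at least 10-fold lower number from compound 1 to compound 3 (1.00 log units; beyond the scatter) and an at least 10-fold lower number from compound 2 to compound 3 (1.00 log units; beyond the scatter). Neither changes this aromatic carbon, so neither sizes the new change directly. Compound 4 does keep the silicon-bearing group on oxygen, whose replacement by hydrogen gave an at least 10-fold lower number from compound 1 to compound 3 (1.00 log units; beyond the scatter). No step beyond the scatter is therefore expected in this assay, and another limit is the likeliest report. The estimated step is a number no higher from compound 1 to compound 4 (the limit leaves the size open). Compound 4 is expected at about 100 ug/mL, with an estimated range of 40 ug/mL to 200 ug/mL.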

Compound 4, half-maximal inhibitory concentration: > 100 ug/mL
Compound 4: a limit, no number; the forecaster's own chance of this, stated with the estimate: 65%; the middle value lies on the limit itself.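

In this assay, for the compounds shown here, compound 4 gives > 100 ug/mL, a limit and not a number, as compound 1 does, so no step between compound 1 and compound 4 can be read: the limit of > 100 ug/mL in this assay, at which 3 of the 4 values shown sit. The compounds shown leave open what methoxymethoxy in place of hydrogen on this aromatic carbon does to the number in this assay.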